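The source may report more compounds than this note shows. Statements on the series, on what has been measured and on what is new or still open speak of the compounds shown alone.

The series rests on a shared core, first seen in compound 1 `Cc1nn(-c2ccccc2)c2ncc(CCCO)cc12`. In a functional assay on THP-1 cells (Homo sapiens) for inhibition, read by ELISA, tested at 10 uM (on this read-out higher numbers stand for more inhibition at the one concentration tested (going by the name of the read-out) and lower numbers for less inhibition), compound 1 gives 19%. Compound 2 `COc1ccc(-c2nn(-c3ccccc3)c3ncc(CCCO)cc23)cc1` carries 4-methoxyphenyl in place of methyl on an aromatic carbon, and in this assay compound 2 gives 36%; the change brought a number 17 percentage points higher from compound 1 to compound 2 (beyond the scatter). Going by the values given here, compound 2 therefore stands highest of the two numbers measured so far, with compound 1 the nearest, below it by a step beyond the scatter.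

Compound 3 `COc1ccc(-c2nn(-c3ccccc3)c3ncc(C(=O)c4cc(C)ccc4O)cc23)cc1` differs from compound 2 in another place: (2-hydroxy-5-methylphenyl)carbonyl in place of 3-hydroxypropyl on an aromatic carbon. Among the compounds with values here, no measured step touches this position; the only step known, from compound 1 to compound 2, concerns the group on the other aromatic carbon, so it cannot guide the size or direction of the present change. With nothing to go on but the much larger group entering, the account expects the value of compound 3 to sit a little above that of compound 2, with a wide range, the expected step being a number 9 percentage points higher from compound 2 to compound 3 (within the scatter). In this assay compound 3 is thus estimated at 45%, between 10% and 85%.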

Compound 3, a percentage reported as inhibition, at one concentration (the size of the read-out at that concentration, not a potency): 49%
Compound 3: middle estimate off by 4 percentage points, on the low side; measured number inside the range.
By their numbers in this assay, from the lowest: compound 1; then compound 2; then compound 3.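

The aromatic carbon that carries 3-hydroxypropyl in compound 1 and compound 2 now proves open to change in this assay: placing (2-hydroxy-5-methylphenyl)carbonyl there gives a number 13 percentage points higher from compound 2 to compound 3 (beyond the scatter), the first step read at this position. The entering group is much larger and brings a six-membered aromatic ring of carbon only, yet the number rises rather than falls, though compound 3 keeps the 4-methoxyphenyl group of compound 2, so the step is read with that group in place only. Nothing at hand speaks to what lies behind this step.

The compounds shown do not separate the contribution of the carbonyl from that of the ring with its hydroxy and methyl groups, so it remains open which part of the entering group goes with the higher number. Also open, from the compounds shown here alone, are what an amine, a carboxylic acid or a longer chain would do at this position, and whether the step would hold with methyl in place of 4-methoxyphenyl on the other aromatic carbon.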